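Carboxy for dimethylsulfamoyl on the aryl ring of compound 3

The source may report more compounds than this note shows. Statements on the series, on what has been measured and on what is new or still open speak of the compounds shown alone.

Series notes. Compound 1 `CCCCCCCCc1ccc(OCC(=O)Cn2nnc(-c3cccc(Cl)c3)n2)cc1` gives 24 nM in an assay on microsomes from brain for inhibition of Fatty-acid amide hydrolase 1 (Rattus norvegicus), read by fluorescence and HPLC, with a stated time of 60 min; on this read-out higher numbers stand for weaker inhibition and lower numbers for stronger inhibition. Within the data shown here, compound 2 `CCCCCCCCc1ccc(OCC(=O)Cn2nnc(-c3ccc(S(=O)(=O)N(C)C)cc3)n2)cc1` gives 590 nM; the step of a 25-fold higher number from compound 1 to compound 2 (1.39 log units; beyond the scatter) is the only one-place change measured so far. Compound 3 `CCCCCCCCc1ccc(OCC(=O)Cn2nnnc2-c2cccc(S(=O)(=O)N(C)C)c2)cc1` gives 1900 nM, the highest number of the three: compound 2 sits closest to it, compound 1 farthest, both gaps beyond the scatter.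

Compound 4 `CCCCCCCCc1ccc(OCC(=O)Cn2nnnc2-c2cccc(C(=O)O)c2)cc1` differs from compound 3 in one place: carboxy in place of dimethylsulfamoyl on an aromatic carbon. Among the measured compounds shown here, no measured step exchanges a dimethylsulfamoyl for a carboxy, so no step bears on it directly; the step from compound 1 to compound 2 changed the aryl substituent, but a different one at a different position, and gives no direction for this exchange. Compound 3 starts from the weakest number, which leaves room either way. Compound 4 is expected to stay near compound 3, at 2500 nM, between 600 nM and 10000 nM. The expected step is a 1.3-fold higher number from compound 3 to compound 4 (0.12 log units; within the scatter), with wide uncertainty.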

Compound 4, half-maximal inhibitory concentration: 1800 nM
Estimate against measurement, compound 4: 1.4-fold (0.14 log units) above; low and high end bracket the measured number.
By their numbers in this assay, from the lowest: compound 1; then compound 2; then compounds 4 and 3 (each within the scatter of the next).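

In this assay, carboxy in place of dimethylsulfamoyl gives a 1.1-fold lower number from compound 3 to compound 4 (0.02 log units; within the scatter), so this exchange on the aromatic carbon does not separate the two compounds. The entering carboxy has fewer heavy atoms than dimethylsulfamoyl and brings a hydrogen-bond donor, yet this difference in composition leaves the pair within the scatter, so the identity of the group at this place is not yet shown to set the number. No supporting data are available to account for this result.

On these data alone, whether a methyl ester or a primary carboxamide at the same place would stay with this pair remains open. Also open, as far as these compounds go, is whether a chlorine on this aromatic carbon would move the number in the core of compound 3, since one exchange alone does not define how this position responds.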